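Working notes on the series: the step to compound 4

The source may hold more compounds than are shown below. What is called first, only, known or untested is meant among the compounds shown, and "the series" means these compounds.

Measured so far, in an ADME assay on Raji cells (Homo sapiens) for cytotoxicity, read by CellTiter-Glo and resazurin assay, with a stated time of 72 h; a lower number here means that less compound is needed, a higher number that more compound is needed for the effect:
- compound 1 `CC(C)COc1cccc(-c2ccc(C(=O)N(Cc3cccc(OCCCCCC(=O)O)c3)C(C)C)cc2)c1`: > 26000 nM, a limit of the assay
- compound 2 `CC(C)N(Cc1cccc(OCCCCCC(=O)O)c1)C(=O)c1ccc(-c2cccc(Cl)c2)cc1`: > 21900 nM, a limit of the assay
- compound 3 `CCOC(=O)CCCCCOc1cccc(CN(C(=O)c2ccc(-c3cccc(OCC(C)C)c3)cc2)C(C)C)c1`: > 26000 nM, a limit of the assay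

Compound 3 stands at the limit of > 26000 nM in this assay, at which 2 of the 3 values shown sit; compound 2 sits at the limit of > 21900 nM in this assay, at which 1 of the 3 values shown sits. No measured value of the series is a number, so compound 3 cannot be ranked against compound 1 or compound 2.

The compound to be measured is compound 4 `CCOC(=O)CCCCCOc1cccc(CN(C(=O)c2ccc(-c3ccc(Cl)c(Cl)c3)cc2)C(C)C)c1`. It differs from compound 3 in one place: 3,4-dichlorophenyl in place of 3-(isobutoxy)phenyl on an aromatic carbon. The measured steps touch this region only loosely: a step that the two limits leave unreadable from compound 1 to compound 2, and a step that the two limits leave unreadable from compound 1 to compound 3. Neither step has a readable size, so they give no direction for the change from compound 3 to compound 4. Given that every measured compound sits at a limit, compound 4 is expected to show a step that the limit leaves unreadable from compound 3 to compound 4, that is, no step beyond the scatter. Compound 4 is estimated at 30000 nM, with a range from 12000 nM to 100000 nM, most likely again reported as a limit.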

Compound 4, half-maximal effective concentration: > 26000 nM
Compound 4: only a limit was reported (the forecaster's own chance of this, stated with the estimate: 75%); the middle value is on the limit's open side.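

Among these compounds, compound 3 and compound 4 are both reported only as limits, so no step between them can be read. The compounds shown leave open whether 3,4-dichlorophenyl in place of 3-(isobutoxy)phenyl changes the result in this assay, where none of them has a numerical value.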